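This account rests on a few compounds, and the source may have more. Where it says the series, first, only, none or still open, it means among the compounds named here.

Compound 1 `COc1cc(C(=O)/C=C/c2ccc(N(C)C)cc2)cc(OC)c1OC`: 75000 nM
Compound 2 `COc1cc(C(=O)/C=C/c2ccc(O)c(O)c2)cc(OC)c1OC`: 19800 nM
Compound 3 `COc1cc(C(=O)/C=C/c2cccc(O)c2)cc(OC)c1OC`: 49000 nM

These values all come from a functional assay on COLO 205 cells (Homo sapiens) for inhibition, read by MTT assay, with a stated time of 48 h; a higher number here means a weaker inhibitor, a lower number a stronger inhibitor. Here compound 3 gives 49000 nM, within the scatter of compound 1, and only compound 2 has a clearly lower number.

The next compound, compound 4 `COc1cc(C(=O)/C=C/c2ccc(Br)cc2)cc(OC)c1OC`, carries 4-bromophenyl in place of 3-hydroxyphenyl on a double-bonded chain carbon bound to a double-bonded chain carbon.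

For the measured compounds named here, one measured step bears on this change: a 2.5-fold higher number from compound 2 to compound 3 (0.39 log units; beyond the scatter). It is modest and concerns hydrogen in place of hydroxy on an aromatic carbon. Compound 4 also lacks a hydroxy group, like compound 1 at 75000 nM, which suggests little gain from that loss. Going by the values given here, no measured step covers bromine, so the direction stays open. In this assay, no change beyond the scatter is expected. The expected step is a 1.1-fold lower number from compound 3 to compound 4 (0.04 log units; within the scatter). For compound 4 the estimated value is 45000 nM, with an expected range of 15000 nM to 110000 nM.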

Compound 4, half-maximal inhibitory concentration: 22500 nM
Compound 4: middle estimate off by 2.0-fold (0.30 log units), on the high side; the measured number falls inside the stated range.
By their numbers in this assay, from the lowest: compounds 2 and 4 (each within the scatter of the next); then compounds 3 and 1 (each within the scatter of the next).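

In this assay the change to 4-bromophenyl on a double-bonded chain carbon bound to a double-bonded chain carbon gives a step beyond the scatter (a 2.2-fold lower number from compound 3 to compound 4 (0.34 log units; beyond the scatter)), so a ring without a hydroxy group can improve on 3-hydroxyphenyl. The step from 3,4-dihydroxyphenyl to 4-bromophenyl stays within the scatter (a 1.1-fold higher number from compound 2 to compound 4 (0.06 log units; within the scatter)), which shows that a hydroxy group is not needed on this ring to reach the lowest numbers in the set. Among the rings without hydroxy, the group on the aromatic carbon also matters, with bromo in place of dimethylamino giving a clear step (a 3.3-fold lower number from compound 1 to compound 4 (0.52 log units; beyond the scatter)).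

No measured evidence explains these steps. Going by these compounds, it remains open whether chloro, methoxy or a carboxylic acid in the place of bromo would match compound 4, and whether an unsubstituted phenyl would do as well.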